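Thiazolidinedione naphthyl ethers against histone deacetylase 8

The source may hold more compounds than are shown below. What is called first, only, known or untested is meant among the compounds shown, and "the series" means these compounds.

Measured so far:
compound 1 `CCOc1ccc2nc(NC(=O)COc3ccc4cc(/C=C5/SC(=O)NC5=O)ccc4c3)sc2c1` — 17000 nM
compound 2 `O=C(COc1ccc2cc(/C=C3/SC(=O)NC3=O)ccc2c1)Nc1cccc(F)n1` — 7200 nM
compound 3 `Cc1cc(Br)ccc1NC(=O)COc1ccc2cc(/C=C3/SC(=O)NC3=O)ccc2c1` — 7400 nM

In an assay on isolated protein for inhibition of histone deacetylase 8 (Homo sapiens), with a stated time of 1 h (on this read-out higher numbers stand for weaker inhibition and lower numbers for stronger inhibition), compound 3 holds the second highest of the three numbers; compound 2 lies within the scatter of it, while compound 1 gives a higher number beyond the scatter. Compound 4 `COc1ccc(NC(=O)COc2ccc3cc(/C=C4/SC(=O)NC4=O)ccc3c2)cc1` differs from compound 3 only on the amide nitrogen: 4-methoxyphenyl in place of 4-bromo-2-methylphenyl on an amide-type nitrogen. Going by the values given here, the one step of the same kind on record, a 1.0-fold higher number from compound 2 to compound 3 (0.01 log units; within the scatter), changed the aryl group on that nitrogen and stayed within the scatter. Compound 1 carries a different change and is not a measured step. For compound 4 the expectation is therefore a step of a 1.0-fold higher number from compound 3 to compound 4 (0.01 log units; within the scatter), that is, no change beyond the scatter in this assay. Compound 4 is estimated at 7500 nM, between 3200 nM and 18000 nM.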

Compound 4, half-maximal inhibitory concentration: > 50000 nM
Compound 4: a limit, no number; the forecaster's own chance of this, stated with the estimate: 5%; at least 6.6-fold (0.82 log units) between middle value and limit.
By their numbers in this assay, from the lowest: compounds 2 and 3 (each within the scatter of the next); then compound 1. At a limit, above all of these: compound 4.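

The aryl group on the amide-type nitrogen proved less tolerant of change than the earlier step suggested: 4-methoxyphenyl there gives an at least 6.7-fold higher number from compound 3 to compound 4 (0.82 log units; beyond the scatter), and also an at least 6.9-fold higher number from compound 2 to compound 4 (0.84 log units; beyond the scatter). For compound 4 the result is a limit and not a number: the limit of > 50000 nM in this assay, at which 1 of the 4 values shown sits. This position can therefore separate compounds beyond the scatter, even though 4-bromo-2-methylphenyl and 6-fluoropyridin-2-yl gave values within the scatter of each other.

The limit leaves the full size of the step open. As far as these compounds go, it also remains open whether the methoxy group or the missing bromine and methyl group accounts for the change, and how 4-bromophenyl or 4-hydroxyphenyl would read at this position.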